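The source may report more compounds than this note shows. Statements on the series, on what has been measured and on what is new or still open speak of the compounds shown alone.

Measured in an ADME assay on HEK293 cells (Homo sapiens) for cytotoxicity, read by reporter gene assay and resazurin assay, with a stated time of 48 h; a higher number here means that more compound is tolerated, a lower number that less compound is tolerated:
- compound 1 `O=C(Nc1cccc(Cl)c1)c1cccc(Br)c1`: 51000 nM
- compound 2 `COc1ccc(Br)cc1C(=O)Nc1ccccc1`: > 100000 nM (a limit)
- compound 3 `O=C(Nc1cccc(Cl)c1)c1cc(Br)ccc1O`: 15000 nM

Of the two values that are numbers, the lower belongs to compound 3 at 15000 nM. For the measured compounds named here, the only measured step is a 3.4-fold lower number from compound 1 to compound 3 (0.53 log units; beyond the scatter), and it is modest. Going by the values given here, the value for compound 2 is a limit and gives no size of step.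

Next is compound 4 `COc1ccc(Br)cc1C(=O)Nc1cccc(Cl)c1`, which has methyl in place of hydrogen on an oxygen on an aromatic ring, turning hydroxy to methoxy: methyl in place of hydrogen on an oxygen on an aromatic ring. Among the compounds with values here, no measured step covers this change directly. The nearest guide is the hydroxy step a 3.4-fold lower number from compound 1 to compound 3 (0.53 log units; beyond the scatter), which lowered the number, so capping that hydroxy may recover part of that loss. Compound 2 also carries methoxy, but it differs from compound 4 elsewhere, so it offers only weak support.

A modest move to a higher number is expected, a 2.3-fold higher number from compound 3 to compound 4 (0.37 log units; beyond the scatter). For compound 4 the estimated value is 35000 nM, with an expected range of 12000 nM to 100000 nM.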

Compound 4, half-maximal cytotoxic concentration: > 100000 nM
Compound 4: no number, only a limit; the forecaster's own chance of this, stated with the estimate: 15%; at least 2.8-fold (0.45 log units) between middle value and limit.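

In this assay, methyl on the oxygen on an aromatic ring gives an at least 6.6-fold higher number from compound 3 to compound 4 (0.82 log units; beyond the scatter), so the lower number of compound 3 does not persist once the hydroxy becomes methoxy. Against hydrogen at the same place the step is an at least 1.9-fold higher number from compound 1 to compound 4 (0.29 log units; that floor lies within the scatter), so methoxy is not shown to differ from hydrogen here, and among compound 1, compound 3 and compound 4 the lower number goes with the free hydroxy alone. Compound 4 gives only a limit, as does compound 2, so the step between them cannot be read: the limit of > 100000 nM in this assay, at which 2 of the 4 values shown sit.

On these data alone, whether an ethoxy or a longer alkoxy chain at this place stays as well tolerated as methoxy remains open. So does the outcome for an amine in place of the hydroxy.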